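Swapping cyclopentyl for cyclopropylmethyl on an aromatic nitrogen

A few compounds are considered here, and "the series" means these few. Any claim that something is new, unique, unknown or untested is made for them only; others in the source may bear on it.

Within the data shown here, in a physicochemical assay for solubility, measured as kinetic solubility (a lower number here means a less soluble compound, a higher number a more soluble compound), compound 1 `CC(=O)Nc1cc(-c2ccc(N(C)C(=O)c3c(F)cccc3Cl)c(N3CC4CC4C3)c2)n(C2CCCC2)n1` gives 0.1 ug/mL as the lowest of the three numbers so far. Compound 2 `CN(C(=O)c1c(F)cccc1Cl)c1ccc(-c2cc(C(N)=O)ccc2Cl)cc1OCC(F)(F)F` gives 0.3 ug/mL and compound 3 `CC(C)n1nc(C(N)=O)cc1-c1ccc(N(C)C(=O)c2c(F)cccc2Cl)c(OCC(F)(F)F)c1` gives 32 ug/mL in the same test. Compound 4 `CC(=O)Nc1cc(-c2ccc(N(C)C(=O)c3c(F)cccc3Cl)c(N3CC4CC4C3)c2)n(CC2CC2)n1` has not yet been measured. It differs from compound 1 by having cyclopropylmethyl in place of cyclopentyl on an aromatic nitrogen and keeps the rest of the structure.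

Among the measured compounds shown here, the one measured step is a 110-fold higher number from compound 2 to compound 3 (2.03 log units; beyond the scatter) and it exchanged one whole aromatic group for another. For the measured compounds named here, it shows how far this read-out can travel, but no measured step changes the group on that nitrogen. That large step therefore gives no size for this much smaller swap. Only a small rise is expected, and a result within the scatter would be no surprise. The expected step is a 2.0-fold higher number from compound 1 to compound 4 (0.30 log units; within the scatter) and it remains an estimate. In this assay the estimate for compound 4 is 0.2 ug/mL with an expected range between 0.05 ug/mL and 1 ug/mL for most repeat measurements.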

Compound 4, solubility: 10.1 ug/mL
Beside the measured number, compound 4's estimate is 51-fold (1.70 log units) below it; the measured number lies above the stated range.
By their numbers in this assay, from the lowest: compound 1; then compound 2; then compound 4; then compound 3.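

In this assay, the group on this aromatic nitrogen proves to be a sensitive point in the structure: the swap gives a 100-fold higher number from compound 1 to compound 4 (2.00 log units; beyond the scatter), and the rest of the molecule stays the same. That single swap moves the read-out about as far as the exchange of one whole aromatic group for another, which gave a 110-fold higher number from compound 2 to compound 3 (2.03 log units; beyond the scatter). Both cyclopentyl and cyclopropylmethyl contain only carbon, with no hydrogen-bond donors or acceptors, so even a change between two such similar groups can matter here, though no measurement at hand explains the size of this step.

From the compounds shown here alone, with only these two groups compared at this nitrogen, it remains open whether the ring size or the carbon link to the ring goes with the rise. It is also unclear where a cyclobutyl group, or a longer chain ending in an amine, would fall relative to compound 1 and compound 4.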